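Removing the Benzyl Group from a Triazine Cytotoxicity Series

This account rests on a few compounds, and the source may have more. Where it says the series, first, only, none or still open, it means among the compounds named here.

Measured compounds:
compound 1, `N#Cc1ccc(Nc2nc(Oc3ccnc4ccccc34)nc(N3CCC(Cc4ccccc4)CC3)n2)cc1C(F)(F)F` — > 100000 nM
compound 2, `N#Cc1ccc(Nc2nc(Oc3ccnc4ccccc34)nc(N3CCN(Cc4ccccc4)CC3)n2)cc1C(F)(F)F` — > 100000 nM

In a functional assay on DU-145 cells (Homo sapiens) for cytotoxicity, read by sulforhodamine B assay, with a stated time of 48 h (a lower number here means that less compound is tolerated, a higher number that more compound is tolerated), compound 1 gives > 100000 nM, which is a limit of the assay rather than a number. Compound 2 likewise gives > 100000 nM in this assay, again a limit. Compound 1 therefore stands at the limit of > 100000 nM in this assay, at which 2 of the 2 values shown sit, and nothing measured here separates it from compound 2.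

Compound 3, `N#Cc1ccc(Nc2nc(Oc3ccnc4ccccc34)nc(N3CCCCC3)n2)cc1C(F)(F)F`, has not yet been measured. It differs from compound 1 by hydrogen in place of benzyl on a saturated ring carbon. Among the compounds with values here, no step between two measured compounds is available, so the size of this change cannot be read from a comparison within the set. Because compound 1 sits at the limit of > 100000 nM in this assay, at which 2 of the 2 values shown sit, in this assay, compound 3 is expected to remain at or near that limit, with no step beyond the scatter. Compound 3 is estimated to give 100000 nM, between 30000 nM and 300000 nM. The expected step of a number no higher from compound 1 to compound 3 (the limit leaves the size open) is essentially none.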

Compound 3, concentration lethal to 50% of the cells: > 100000 nM
Compound 3: no number, only a limit; the forecaster's own chance of this, stated with the estimate: 80%; the middle value sits exactly at the limit.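

No step can be read from compound 1 to compound 3 in this assay, as each gives only a limit of the assay: the limit of > 100000 nM in this assay, at which 3 of the 3 values shown sit. The compounds shown leave open whether hydrogen in place of benzyl on a saturated ring carbon changes cytotoxicity at all.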